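The source may hold more compounds than are shown below. What is called first, only, known or untested is meant among the compounds shown, and "the series" means these compounds.

Compound 1 `CCOC(=O)/C=C/c1ccncc1-c1ccc2[nH]ccc2c1` gives in a functional assay on MCF7 cells (Homo sapiens) for inhibition, read by sulforhodamine B assay, with a stated time of 72 h (a lower number here means a stronger inhibitor of growth, a higher number a weaker inhibitor of growth), only the limit > 10000 nM.
Compound 2 `CNC(=O)/C=C/c1ccncc1-c1ccc2[nH]ccc2c1` gives in this assay only the limit > 10000 nM.
Compound 3 `CNC(=O)CCc1ccncc1-c1ccc2ccccc2c1` gives in this assay only the limit > 10000 nM.

Compound 3 therefore stands at the limit, where every value shown sits (the limit of > 10000 nM in this assay, at which 3 of the 3 values shown sit). For the measured compounds named here, the only measured step, a step that the two limits leave unreadable from compound 1 to compound 2, bears on a different part of the structure and cannot be read. Compound 4 `CNC(=O)/C=C/c1ccncc1-c1ccc2ccccc2c1` differs from compound 3 by 2-(methylcarbamoyl)ethenyl in place of 2-(methylcarbamoyl)ethyl on an aromatic carbon. Going by the values given here, no measured step changes this group, so its size cannot be estimated from data. Compound 1 already carries the 2-(methylcarbamoyl)ethenyl group and gives only a limit. Compound 2 carries it too and likewise gives only a limit. Compound 4 is expected to give 15000 nM, between 5000 nM and 50000 nM, so the expected step that the limit leaves unreadable from compound 3 to compound 4 is none beyond the scatter.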

Compound 4, concentration for 50% growth inhibition: 9340 nM
Estimate against measurement, compound 4: 1.6-fold (0.21 log units) above; low and high end bracket the measured number.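

Compound 4 is the first compound shown to give a number rather than a limit in this assay, so the change at this aromatic carbon, opposite the ring nitrogen, now has a measurable floor: an at least 1.0-fold lower number from compound 3 to compound 4 (0.02 log units; that floor lies within the scatter). As that floor lies within the scatter, the change is not shown to give stronger growth inhibition. Compound 1, compound 2 and compound 3 remain at a limit: the limit of > 10000 nM in this assay, at which 3 of the 4 values shown sit.

As far as these compounds go, how far compound 3 truly lies from compound 4 stays open. So does whether an amine, a carboxylic acid or a longer chain at this position would give a clearly lower number in this assay.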